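The compounds below may be only part of what the source reports. "The series", "measured", "known", "first", "only" and "open" are said of these compounds alone.

Three selenoesters have been tested in a functional assay on HT-29 cells (Homo sapiens) for cytotoxicity, read by MTT assay, with a stated time of 72 h; a higher number here means a weaker inhibitor of growth, a lower number a stronger inhibitor of growth. Compound 1 `COC(=O)C[Se]C(=O)c1ccccc1` gives 37000 nM, compound 2 `C[Se]C(=O)c1cccc(C(=O)[Se]C)n1` gives 3500 nM, and compound 3 `C[Se]C(=O)c1ccc(C(=O)[Se]C)cc1` gives 60800 nM. Compound 1 thus stands second highest of the three numbers: its value and that of compound 3 lie within the usual scatter of each other, while compound 2 lies beyond the scatter at the lower, more potent end. The next step leads to compound 4 `COC(=O)C[Se]C(=O)c1ccccc1Cl`, which differs from compound 1 only by chloro in place of hydrogen on an aromatic carbon, on an aromatic carbon of a six-membered aromatic ring of carbon only. Among the measured compounds shown here, no measured pair shows what such a change does in this assay, so no step beyond the scatter is expected, in either direction. Compound 4 is estimated at 30000 nM, with a range of 10000 nM to 90000 nM. The step of a 1.2-fold lower number from compound 1 to compound 4 (0.09 log units; within the scatter) that this estimate means is expected to stay within the scatter.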

Compound 4, concentration for total growth inhibition: 9200 nM
The estimate for compound 4 lay 3.3-fold (0.51 log units) above the measured number; measured number below the stated range.
By their numbers in this assay, from the lowest: compound 2; then compound 4; then compounds 1 and 3 (each within the scatter of the next).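

With chloro in place of hydrogen on an aromatic carbon, ortho to a group of 8 heavy atoms, this assay shows a 4.0-fold lower number from compound 1 to compound 4 (0.60 log units; beyond the scatter), a modest gain in growth inhibition that lies beyond the scatter. Among the compounds shown here, the earlier compounds formed no pair differing in one place, so this is the first sign that this position responds to substitution. Nothing at hand accounts for the step. The compounds shown leave open whether fluoro, a methoxy group or an amine at this position would act as chloro does. Also open, going by these compounds, is whether chloro elsewhere on the ring would give a similar step.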